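The source may report more compounds than this note shows. Statements on the series, on what has been measured and on what is new or still open speak of the compounds shown alone.

Compound 1 `C/C=C/C(=O)Nc1cccc(Cn2nc(-c3ccc(Oc4ccccc4)cc3)cc2C(=O)O)c1` carries a carboxy group on the shared core. In a functional assay on JeKo-1 cells (Homo sapiens) for inhibition, read by luminescence and CellTiter-Glo, with a stated time of 72 h (a higher number here means a weaker inhibitor, a lower number a stronger inhibitor), compound 1 reaches only the limit of the assay, > 60000 nM, so no number is known for it and it stands at the top edge of what was measured. That limit, (the limit of > 60000 nM in this assay, at which 1 of the 2 values shown sits), is where one of the two values recorded sits. Compound 2 `C/C=C/C(=O)Nc1ccc(Cn2nc(-c3ccc(Oc4ccccc4)cc3)cc2C(=O)OCC)cc1`, an ethyl ester relative of the same core, gives 52500 nM in this assay, a number that sits close to the same edge. Compound 3 `C/C=C/C(=O)Nc1cccc(Cn2nc(-c3ccc(Oc4ccccc4)cc3)cc2CO)c1` changes only the acid: hydroxymethyl in place of carboxy on an aromatic carbon. Among the measured compounds shown here, no measured pair shows this change, so the size of the step is a guess. Because compound 1 sits at the limit, > 60000 nM, only a move toward stronger inhibition could become visible, and none beyond the scatter is expected. The step expected is an at least 1.2-fold lower number from compound 1 to compound 3 (0.07 log units; that floor lies within the scatter). Compound 3 is expected to give about 50000 nM, between 15000 nM and 60000 nM.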

Compound 3, half-maximal inhibitory concentration: 22600 nM
For compound 3 the middle estimate is 2.2-fold (0.34 log units) above the measured one; low and high end bracket the measured number.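

In this assay, hydroxymethyl in place of carboxy on this aromatic carbon gives an at least 2.6-fold lower number from compound 1 to compound 3 (0.42 log units; beyond the scatter). Among the compounds shown here, this is the first readable evidence that the group at this place on the shared core can change the measured number, which compounds 1 and 2 could not show, as they differ in more than one place. Only the smallest possible size of this step is known, and its full size stays open, since for compound 1 there is only a limit of the assay: the limit of > 60000 nM in this assay, at which 1 of the 3 values shown sits.

The compounds shown do not say whether the change comes from losing the carboxy group or from gaining the hydroxymethyl group. They also leave open how an amine or a methyl ether at this same place would read in this assay.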